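Aminolactone amides: chain length and cytotoxicity in cell assay

The compounds below may be only part of what the source reports. "The series", "measured", "known", "first", "only" and "open" are said of these compounds alone.

Measured so far in a functional assay on NCI-H630 cells (Homo sapiens) for cytotoxicity, read by sulforhodamine B assay, with a stated time of 5 days; on this read-out lower numbers stand for stronger inhibition and higher numbers for weaker inhibition:
compound 1 `O=C(CCCc1ccccc1)N[C@H]1CCOC1=O` — > 100000 nM
compound 2 `O=C(CCCc1ccccc1)CC(=O)N[C@H]1CCOC1=O` — > 100000 nM
compound 3 `O=C(CCCCCCCCCCc1ccccc1)CC(=O)N[C@H]1CCOC1=O` — 14000 nM

The value of compound 1 is a limit of the assay, not a number. The value of compound 2 is likewise a limit of the assay, not a number. Compound 2 thus stands at the limit of > 100000 nM in this assay, at which 2 of the 3 values shown sit, together with compound 1, while compound 3 alone gives a numerical reading, obtained with the longest chain between the carbonyl and the aromatic ring among the three. Going by the values given here, no step between two measured compounds that differ in a single place is available, so nothing can be said of the size of any single change from measurement alone.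

Compound 4 `O=C(CCc1ccccc1)CC(=O)N[C@H]1CCOC1=O` is not yet measured. It differs from compound 2 as follows: phenyl in place of benzyl on a saturated chain carbon, two bonds along the chain from a carbonyl carbon. Among the compounds with values here, the change shortens the chain carrying the aromatic ring, moving further from compound 3, the only compound with a number. In this assay the step from compound 2 to compound 4 is expected to be none beyond the scatter, since compound 2 sits at the limit. Compound 4 is expected to give about 150000 nM, within 50000 nM to 500000 nM, most probably again only a limit, with the expected step that the limit leaves unreadable from compound 2 to compound 4.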

Compound 4, half-maximal inhibitory concentration: > 100000 nM
Compound 4: no number, only a limit; the forecaster's own chance of this, stated with the estimate: 85%; the middle value is on the limit's open side.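

Compound 2 and compound 4 both give only a limit in this assay, not a number, so no step can be read for this pair: the limit of > 100000 nM in this assay, at which 3 of the 4 values shown sit.

Left open is at which chain length, from that of compound 2 up to that of compound 3 at 14000 nM, a numerical reading first appears.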